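A few compounds are considered here, and "the series" means these few. Any claim that something is new, unique, unknown or untested is made for them only; others in the source may bear on it.

Compound 2 `O=C(/C=C/c1cc2ccccc2[nH]c1=O)c1ccc(O)cc1` and compound 1 `COc1ccc(C(=O)/C=C/c2cc3ccccc3[nH]c2=O)cc1` share the same core and differ only by hydrogen in place of methyl on an oxygen on the aromatic ring. In an ADME assay on MDA-MB-468 cells (Homo sapiens) for cytotoxicity, read by sulforhodamine B assay, with a stated time of 24 h (on this read-out lower numbers stand for higher toxicity in this test and higher numbers for lower toxicity in this test), compound 1 gives 39800 nM, while compound 2 gives 19800 nM. The step of a 2.0-fold lower number from compound 1 to compound 2 (0.30 log units; within the scatter) is the only one measured, and since it stays within the scatter, compound 2 holds the lower of the two numbers without being separable from compound 1. Compound 3 `O=C(/C=C/c1cc2ccccc2[nH]c1=O)c1ccc(Cl)cc1` carries the change (chloro in place of hydroxy on an aromatic carbon). Within the data shown here, no measured step exchanges hydroxy for chloro, and the one measured change on that ring stayed within the scatter. In this assay compound 3 is therefore expected to show a step of a 1.3-fold lower number from compound 2 to compound 3 (0.12 log units; within the scatter), small enough that it could fall in either direction. The estimate for compound 3 is 15000 nM, with a range from 4000 nM to 60000 nM.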

Compound 3, concentration lethal to 50% of the cells: 53200 nM
Compound 3: middle estimate off by 3.5-fold (0.55 log units), on the low side; measured number inside the range.
By their numbers in this assay, from the lowest: compounds 2, 1 and 3 (each within the scatter of the next, the first and the last beyond it).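

In this assay, among these compounds, the exchange of hydroxy for chloro on this aromatic carbon, para to a large group, gives a 2.7-fold higher number from compound 2 to compound 3 (0.43 log units; beyond the scatter) and so provides the first modest step that lies beyond the scatter. Chloro in place of methoxy at the same carbon gives a 1.3-fold higher number from compound 1 to compound 3 (0.13 log units; within the scatter) and stays within the scatter, so compound 3 can be separated from compound 2 but not from compound 1, and the substituents at this position are only partly told apart. No evidence is available that would account for this difference between the substituents.

The compounds shown leave open how an amine, a carboxylic acid or a fluoro group on this carbon would read in this test. They also leave open whether the gap between hydroxy and chloro would persist on a different core.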